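An Ethoxy Group Takes the Place of Chlorine

The source may report more compounds than this note shows. Statements on the series, on what has been measured and on what is new or still open speak of the compounds shown alone.

Compound 1 `COc1ccc2c(=O)c(/C=C/C(=O)Nc3cccc(Cl)c3)coc2c1` was tested in a functional assay (QGY7701 cells, Homo sapiens) for inhibition, read by MTT assay, with a stated time of 48 h; on this read-out lower numbers stand for stronger inhibition and higher numbers for weaker inhibition. There compound 1 reaches only a limit of the assay, > 100000 nM. Compound 2 `COc1ccc2c(=O)c(/C=C/C(=O)Nc3ccc(Cl)cc3)coc2c1` likewise gives only a limit in this assay, > 100000 nM. Compound 3 `COc1ccc2c(=O)c(/C=C/C(=O)Nc3ccc(C)cc3)coc2c1` gives a number in this assay, 39300 nM. Two of the three values sit at the limit of > 100000 nM in this assay, at which 2 of the 3 values shown sit, so compound 1 stands at the weak end of what has been measured. Compound 4 `CCOc1ccc(NC(=O)/C=C/c2coc3cc(OC)ccc3c2=O)cc1` differs from compound 1 by 4-ethoxyphenyl in place of 3-chlorophenyl on an amide-type nitrogen. The nearest measured steps are an at least 2.5-fold lower number from compound 1 to compound 3 (0.40 log units; beyond the scatter) and an at least 2.5-fold lower number from compound 2 to compound 3 (0.40 log units; beyond the scatter), both moving from a chlorine-bearing phenyl to a 4-methylphenyl. A similar modest drop is therefore expected, an at least 2.2-fold lower number from compound 1 to compound 4 (0.34 log units; beyond the scatter). Compound 4 is estimated at 45000 nM, between 15000 nM and 150000 nM.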

Compound 4, half-maximal inhibitory concentration: > 100000 nM
Compound 4: only a limit was reported (the forecaster's own chance of this, stated with the estimate: 35%); middle value at least 2.2-fold (0.34 log units) away from the limit.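

Ethoxy in place of methyl gives an at least 2.5-fold higher number from compound 3 to compound 4 (0.40 log units; beyond the scatter), so a para-free reading is not needed: among the compounds shown, only 4-methylphenyl on the amide-type nitrogen yields a readable number. Compound 4 reaches only a limit of the assay, so its steps from compound 1 and compound 2, which also stop at limits, cannot be read. Compound 3 therefore remains the lone readable value in the set: the limit of > 100000 nM in this assay, at which 3 of the 4 values shown sit.

Still open, going by these compounds, is whether the activity of compound 3 is particular to methyl or would also appear with a 4-ethylphenyl or a 4-aminophenyl on the same nitrogen. On these data alone, how far compound 1, compound 2 and compound 4 lie beyond the limit also stays unknown.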